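Acetyl on the Phenol of a Coumarin-Triazole Indole

The source may report more compounds than this note shows. Statements on the series, on what has been measured and on what is new or still open speak of the compounds shown alone.

Compound 1, `COc1ccc(-c2cn(-c3cc4ccc(O)c(C)c4oc3=O)nn2)cc1`, is the starting point. In a functional assay on MCF7 cells (Homo sapiens) for antiproliferative activity (on this read-out lower numbers stand for stronger inhibition and higher numbers for weaker inhibition), compound 1 gives > 100000 nM, which is a limit of the assay and not a number. Compound 2, `COc1ccc(-c2cn(-c3cc4ccc(OC(C)=O)c(C)c4oc3=O)nn2)cc1`, carries acetyl in place of hydrogen on an oxygen on an aromatic ring. In this assay compound 2 gives > 100000 nM, again a limit of the assay rather than a number. Between the two the step is a step that the two limits leave unreadable from compound 1 to compound 2, since the limit of > 100000 nM in this assay, at which 2 of the 3 values shown sit, covers both of them.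

Compound 3, `Cc1c(O)ccc2cc(-n3cc(-c4cc5ccccc5[nH]4)nn3)c(=O)oc12`, differs from compound 1 by 1H-indol-2-yl in place of 4-methoxyphenyl on an aromatic carbon. In this assay, among the compounds with values here, compound 3 gives 38300 nM, the only measured number among the three. That change gives an at least 2.6-fold lower number from compound 1 to compound 3 (0.41 log units; beyond the scatter).

Compound 4, `CC(=O)Oc1ccc2cc(-n3cc(-c4cc5ccccc5[nH]4)nn3)c(=O)oc2c1C`, has not been measured. It differs from compound 3 by acetyl in place of hydrogen on an oxygen on an aromatic ring. Within the data shown here, this is the same kind of change as the one from compound 1 to compound 2, and the place lines read the same word for word, so the surroundings of the change match. The earlier instance of this change, a step that the two limits leave unreadable from compound 1 to compound 2, gives no readable size, so nothing about direction or magnitude can be carried over from it. For compound 4 the step is therefore expected to be about a 1.2-fold higher number from compound 3 to compound 4 (0.07 log units; within the scatter), resting only on the fact that compound 3 gives 38300 nM and the acetyl change has no measured effect on record. Compound 4 is thus estimated at 45000 nM, within roughly 15000 nM to 150000 nM.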

Compound 4, half-maximal inhibitory concentration: 76100 nM
Beside the measured number, compound 4's estimate is 1.7-fold (0.23 log units) below it, within the range that was stated.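

The swap of 4-methoxyphenyl for 1H-indol-2-yl, read on the core carrying the acetyl, is an at least 1.3-fold lower number from compound 2 to compound 4 (0.11 log units; that floor lies within the scatter), and set beside the same swap on the core with the free hydroxy group it reads: the same change on two cores in this assay, an at least 2.6-fold lower number (0.41 log units; beyond the scatter) from compound 1 to compound 3 and an at least 1.3-fold lower number (0.11 log units; that floor lies within the scatter) from compound 2 to compound 4; the limit leaves it open whether they differ. So the swap gives a step beyond the scatter on the hydroxy core, while on the acetyl core the printed floor stays within the scatter, and this does not show whether the swap is worth the same on both cores or a different amount. The acetyl change itself gives a 2.0-fold higher number from compound 3 to compound 4 (0.30 log units; within the scatter) with the 1H-indol-2-yl group in place, but that single reading cannot be compared with the step with 4-methoxyphenyl in place, which cannot be read, as both of those compounds stand at a limit of the assay: the limit of > 100000 nM in this assay, at which 2 of the 4 values shown sit.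

From the compounds shown here alone, only hydrogen and acetyl appear on this oxygen, so it remains open how a longer chain such as butanoyl, or a chain ending in an amine, would read in this assay. It also remains open whether a group other than the two shown on the triazole, such as a carboxylic acid on the phenyl ring, would bring the numbers lower.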